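Working notes: from compound 1 to compound 4

The source may hold more compounds than are shown below. What is called first, only, known or untested is meant among the compounds shown, and "the series" means these compounds.

Measured so far in a functional assay on HCT-116 cells (Homo sapiens) for inhibition, read by colorimetric assay, with a stated time of 3 days; a higher number here means a weaker inhibitor, a lower number a stronger inhibitor:
Compound 1 `O=C(CCCCCCNC(=O)C(O)(O)C(F)(F)F)Nc1ccccc1` gives 9140 nM
Compound 2 `COc1ccccc1NC(=O)CCCCCCNC(=O)C(O)(O)C(F)(F)F` gives 10100 nM
Compound 3 `O=C(CCCCCCNC(=O)C(O)(O)C(F)(F)F)Nc1c(F)cc(F)cc1F` gives 22200 nM

Compound 1 stands at the low end of these numbers, level with compound 2 within the scatter, with compound 3 higher. Compound 4 `O=C(CCCCCCNC(=O)C(O)(O)C(F)(F)F)Nc1ccc(S(F)(F)(F)(F)F)cc1` differs from compound 1 by a group of 6 heavy atoms (5 fluorine, 1 sulfur; no ring) in place of a hydrogen atom, on an aromatic carbon, para to a large group. Two measured steps alter the aromatic ring, and neither introduces this group. Methoxy in place of hydrogen gave a 1.1-fold higher number from compound 1 to compound 2 (0.04 log units; within the scatter), while 2,4,6-trifluorophenyl in place of phenyl gave a 2.4-fold higher number from compound 1 to compound 3 (0.39 log units; beyond the scatter). On that basis, no step beyond the scatter is expected in this assay, and no direction is favoured. The expected change is a 1.0-fold lower number from compound 1 to compound 4 (0.01 log units; within the scatter). For compound 4 the estimated value is 9000 nM, with an expected range of 3500 nM to 23000 nM.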

Compound 4, half-maximal inhibitory concentration: 9110 nM
Compound 4: the middle estimate sits 1.0-fold (0.01 log units) below what was measured, within the range that was stated.
By their numbers in this assay, from the lowest: compounds 4, 1 and 2 (each within the scatter of the next); then compound 3.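

In this assay, a 1.0-fold lower number from compound 1 to compound 4 (0.00 log units; within the scatter) shows that a group of 6 heavy atoms (5 fluorine, 1 sulfur; no ring) can stand on this aromatic carbon, para to a large group, without a step beyond the scatter. Among the ring changes shown, only those to compound 3 remain beyond the scatter. Nothing measured here bears on why the number stays level.

As far as these compounds go, whether an amine or a carboxylic acid on this same aromatic carbon would also leave the number level stays open. So does the outcome of a longer chain in the shared core.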